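The compounds below may be only part of what the source reports. "The series", "measured", "known", "first", "only" and "open" are said of these compounds alone.

Measured so far:
- Compound 1, `CN(C)CCCOc1ccc(CN(C)c2nc3ccc(Oc4ccc(C(F)(F)F)cc4)cc3s2)cc1`, gives 54000 nM in an assay on cells for inhibition of Voltage-dependent T-type calcium channel subunit alpha-1H (Homo sapiens), read by FLIPR and calcium flux, with stated times of 600 s and 300 s; a higher number here means a weaker inhibitor, a lower number a stronger inhibitor.
- Compound 2, `CN(Cc1ccc(OCCCN)cc1)c1nc2ccc(Oc3ccc(C#N)cc3)cc2s1`, gives 328000 nM in this assay.
- Compound 3, `NCCCOc1ccc(CNc2nc3ccc(Oc4ccc(O)cc4)cc3s2)cc1`, gives 300000 nM in this assay.

Among these three numbers compound 3 stands second highest. Its nearest neighbour is compound 2, whose value lies within the scatter of that of compound 3, so the two cannot be told apart. Compound 1 stands well apart from compound 3, with a clearly lower number, beyond the scatter.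

Compound 4, `NCCCOc1ccc(CNc2nc3ccc(Oc4ccc(C(F)(F)F)cc4)cc3s2)cc1`, has not yet been measured. It differs from compound 3 in one place: trifluoromethyl in place of hydroxy on an aromatic carbon. Within the data shown here, compound 1 is the only measured compound that carries a trifluoromethyl at this position, and it gives the lowest number, but compound 1 also differs from compound 3 elsewhere, so its value cannot be tied to the trifluoromethyl alone. On this thin ground a modest step towards a lower number is expected, a 2.5-fold lower number from compound 3 to compound 4 (0.40 log units; beyond the scatter), though a result within the scatter would not surprise. The estimate for compound 4 is 120000 nM, with a range from 35000 nM to 350000 nM.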

Compound 4, half-maximal inhibitory concentration: 112000 nM
Compound 4: middle estimate off by 1.1-fold (0.03 log units), on the high side; the range from low to high includes it.
By their numbers in this assay, from the lowest: compound 1; then compound 4; then compounds 3 and 2 (each within the scatter of the next).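

Among these compounds, compound 3 and compound 4 differ in one place only, so this pair gives the first clean reading of the group para to a large group on the outer aromatic ring: the change from 4-hydroxyphenoxy to 4-(trifluoromethyl)phenoxy gives a 2.7-fold lower number from compound 3 to compound 4 (0.43 log units; beyond the scatter) in this assay and lies beyond the usual scatter. This position therefore has a modest but readable effect on the number, although compound 4 still gives 112000 nM and remains far up the micromolar range. The swap removes the hydroxy group's hydrogen-bond donor and acceptor and adds more heavy atoms, and nothing shown here separates these differences or explains the step.

On these data alone, it remains open how a methoxy group, a single fluorine or an amine at this position would compare with hydroxy and trifluoromethyl. It is also unknown whether the same swap would give a similar step with other groups elsewhere on the molecule.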